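The compounds below may be only part of what the source reports. "The series", "measured", "known", "first", "only" and "open" are said of these compounds alone.

In a functional assay on BXPC-3 cells (Homo sapiens) for antiproliferative activity, read by MTT assay, with a stated time of 24 h (on this read-out higher numbers stand for weaker inhibition and lower numbers for stronger inhibition), three compounds sharing one core have been measured. Compound 1 `CCn1c(C(=O)N[C@@H](C)C(=O)OC)ccc1C(CC)(CC)c1ccc(OCS(=O)(=O)c2ccccc2)c(C)c1` gives 17900 nM. Compound 2 `CCn1c(C(=O)N[C@H](C)C(=O)OC)ccc1C(CC)(CC)c1ccc(OCS(=O)(=O)c2ccccc2)c(C)c1` reads > 50000 nM, which is a limit of the assay. Compound 3 `CCn1c(C(=O)NCCNC(=O)OC(C)(C)C)ccc1C(CC)(CC)c1ccc(OCS(=O)(=O)c2ccccc2)c(C)c1` reads > 50000 nM, and this too is a limit. Compound 3 therefore has no number of its own and stands at the limit of > 50000 nM in this assay, at which 2 of the 3 values shown sit.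

Two steps can be read, at least in part. The first, an at least 2.7-fold higher number from compound 1 to compound 2 (0.44 log units; beyond the scatter), comes with the fact that compounds 1 and 2 differ only in the configuration as drawn. The second, an at least 2.7-fold higher number from compound 1 to compound 3 (0.44 log units; beyond the scatter), changes the group on the amide-type nitrogen and bears most closely on what follows. By contrast, a step that the two limits leave unreadable from compound 2 to compound 3 gives no usable size.

Compound 4 `CCN(CC)CCNC(=O)c1ccc(C(CC)(CC)c2ccc(OCS(=O)(=O)c3ccccc3)c(C)c2)n1CC` keeps the core of compound 3, and the change is diethylamino in place of (tert-butoxycarbonyl)amino on a saturated chain carbon, two bonds along the chain from an amide-type nitrogen. In words, diethylamino stands in place of (tert-butoxycarbonyl)amino on a saturated chain carbon, two bonds along the chain from an amide-type nitrogen. Among the compounds with values here, no measured step exchanges these two groups, so the expectation is loose. Within the data shown here, it leans on compound 1 at 17900 nM, the only measured number in this set. A modest move toward stronger inhibition is expected, as an at least 1.7-fold lower number from compound 3 to compound 4 (0.25 log units; that floor lies within the scatter), though a second limit would be no surprise. For compound 4 the estimate is 28000 nM, with an expected range from 9000 nM to 50000 nM.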

Compound 4, half-maximal inhibitory concentration: 6270 nM
For compound 4 the middle estimate is 4.5-fold (0.65 log units) above the measured one; the measured number lies below the stated range.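

In this assay, this position turns out to be able to move the read-out toward stronger inhibition, and not only away from it: 2-(diethylamino)ethyl in place of 1-(methoxycarbonyl)ethyl on the amide-type nitrogen gives a 2.9-fold lower number from compound 1 to compound 4 (0.46 log units; beyond the scatter). The same exchange, measured against a compound that reads only as a limit, gives an at least 7.9-fold lower number from compound 2 to compound 4 (0.90 log units; beyond the scatter). The closest comparison is an at least 7.9-fold lower number from compound 3 to compound 4 (0.90 log units; beyond the scatter), where the ethyl chain stays and only its end group changes from (tert-butoxycarbonyl)amino to diethylamino, so the chain alone does not decide the outcome, and this step and the one before it are floors rather than sizes: the limit of > 50000 nM in this assay, at which 2 of the 4 values shown sit.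

The compounds shown leave open whether the gain follows the amine nitrogen or the ethyl groups on it, which a primary amine, a dimethylamino group or a morpholine on the same chain would help to separate. They also leave open how the read-out responds to a longer chain between the amide-type nitrogen and the diethylamino group.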